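A few compounds are considered here, and "the series" means these few. Any claim that something is new, unique, unknown or untested is made for them only; others in the source may bear on it.

Compound 1 `CC1=CC[C@@H]([C@@](C)(O)CCCC(C)(C)NC(=S)NN)CC1` gives 26800 nM
Compound 2 `CC1=CC[C@@H]([C@@](C)(O)CCCC(C)(C)NC(=S)N/N=C\c2ccc(C)cc2)CC1` gives 6750 nM

In a functional assay on PCO3 cells (Homo sapiens) for cytotoxicity, read by sulforhodamine B assay (a lower number here means a stronger inhibitor of growth, a higher number a weaker inhibitor of growth), compound 1 at 26800 nM holds the higher of the two numbers. The change a group of 9 heavy atoms (7 carbon, 1 nitrogen, 1 oxygen; one six-membered aromatic ring of carbon only) in place of one nitrogen atom, on an amide-type nitrogen leads to compound 3 `CC1=CC[C@@H]([C@@](C)(O)CCCC(C)(C)NC(=S)N/N=C\c2ccc(O)cc2)CC1` and sits on an amide-type nitrogen whose other neighbour is the thiocarbonyl carbon. For the measured compounds named here, the one measured step that bears on it (a modest one) is a 4.0-fold lower number from compound 1 to compound 2 (0.60 log units; beyond the scatter) and also brings in a six-membered aromatic ring of carbon only at that place. A step of about that size toward a lower number is therefore expected in this assay, though a single step is thin support. The expected change is a 3.6-fold lower number from compound 1 to compound 3 (0.55 log units; beyond the scatter) as estimated here. Compound 3 is estimated at 7500 nM (range 3000 nM to 18000 nM).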

Compound 3, concentration for 50% growth inhibition: 6230 nM
Compound 3: the middle estimate sits 1.2-fold (0.08 log units) above what was measured, and the stated range covers the measured number.
By their numbers in this assay, from the lowest: compounds 3 and 2 (each within the scatter of the next); then compound 1.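

In this assay, a group bearing an aromatic ring in place of the amino on the amide-type nitrogen again lowers the number, with a 4.3-fold lower number from compound 1 to compound 3 (0.63 log units; beyond the scatter), so the drop does not rest on the methyl of compound 2. Hydroxy in place of methyl on an aromatic carbon gives a 1.1-fold lower number from compound 2 to compound 3 (0.03 log units; within the scatter), so these two groups cannot be told apart here. No measurement at hand explains the drop.

On these data alone, whether chlorine or an amine on that ring would shift the number stays open. So does whether a plain alkyl chain in place of the ring would give the same drop.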